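The source may hold more compounds than are shown below. What is called first, only, known or untested is meant among the compounds shown, and "the series" means these compounds.

Measured so far:
compound 1 `COc1cccc(N2CCN(C(=O)c3oc(C(F)(F)F)nc3-c3cccc(F)c3)CC2)c1` — a functional assay on HL-60 cells (Homo sapiens) for inhibition, read by MTT assay, with a stated time of 72 h; a lower number here means a stronger inhibitor, a higher number a weaker inhibitor: "not active" (no number reported)
compound 2 `Cc1ccc(N2CCN(C(=O)c3oc(C)nc3-c3ccccc3)CC2)cc1` — this assay: > 1000 nM
compound 3 `Cc1nc(-c2ccccc2F)c(C(=O)N2CCN(c3cc(Cl)ccc3C)CC2)o1` — this assay: 229 nM

Compound 2 stands at the limit of > 1000 nM in this assay, at which 1 of the 3 values shown sits; its entry is a limit of the assay and not a number. Among the compounds with values here, compound 1 has no number at all, so compound 3 is the only one of the three with a numerical value, and no step between measured compounds can be computed.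

Compound 4 `Cc1ccc(C)c(N2CCN(C(=O)c3oc(C)nc3-c3ccccc3)CC2)c1` is the next to be run. It differs from compound 2 by 2,5-dimethylphenyl in place of 4-methylphenyl on an amine nitrogen in a ring. Compound 3 carries a ring with two substituents at the same place on its core and gives a number, whereas compound 2 with one substituent there gives only a limit; the two also differ elsewhere, so this shows only what the two values show. In this assay the step is expected to run toward a stronger inhibitor, by more than the usual scatter, and the step of an at least 1.4-fold lower number from compound 2 to compound 4 (0.15 log units; that floor lies within the scatter) is the expected size. Compound 4 is estimated at 700 nM, with a range from 200 nM to 2500 nM.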

Compound 4, half-maximal inhibitory concentration: 31.3 nM
For compound 4 the middle estimate is 22-fold (1.35 log units) above the measured one; measured number below the stated range.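

In this assay, the group on the amine nitrogen of the six-membered non-aromatic ring now has a reading in which nothing else changes: 2,5-dimethylphenyl in place of 4-methylphenyl gives an at least 31-fold lower number from compound 2 to compound 4 (1.50 log units; beyond the scatter). Compound 2 carries a limit and not a number, so this step is a floor: the limit of > 1000 nM in this assay, at which 1 of the 4 values shown sits. With the rest of the structure held fixed, activity in this assay clearly responds to the aryl group at this place, which compound 1, compound 2 and compound 3 could not show, as they differ from one another in more than one place.

On these data alone, how much of the step belongs to each methyl of the 2,5-dimethylphenyl group stays open. Also open, as far as these compounds go, is whether an ethyl, an amine or a carboxylic acid on that phenyl ring would hold this level.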